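The source may hold more compounds than are shown below. What is called first, only, known or untested is meant among the compounds shown, and "the series" means these compounds.

In a functional assay on M21 cells (Homo sapiens) for inhibition, read by sulforhodamine B assay, with a stated time of 48 h (a higher number here means a weaker inhibitor of growth, a lower number a stronger inhibitor of growth), compound 1 `CC(C)(C)c1ccc(NC2=NCCO2)cc1` gives 2400 nM, compound 2 `O=C(CCl)NC(=O)Nc1cccc(OC2CCCC2)c1` gives 3500 nM, and compound 3 `O=C(CCl)NC(=O)Nc1ccc(Oc2ccccc2)cc1` gives 4200 nM. Compound 2 stands within the usual scatter of both other compounds, so these numbers do not set it apart from either. Compound 4 `O=C(CCl)NC(=O)Nc1cccc(Oc2ccccc2)c1` differs from compound 2 in one place, with phenyl in place of cyclopentyl on an oxygen on an aromatic ring. Among the measured compounds shown here, no measured pair shows this change alone, so the expectation rests on indirect evidence. Compound 3 also carries a phenoxy group, and its 4200 nM lies within the scatter of the value for compound 2. No step beyond the scatter is therefore expected in this assay, and the direction of any small shift cannot be told from these data. The expected step is a 1.1-fold higher number from compound 2 to compound 4 (0.04 log units; within the scatter), which stays within the scatter. For compound 4, the estimated value is 3800 nM, with an expected range from 1700 nM to 8500 nM.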

Compound 4, concentration for 50% growth inhibition: 5300 nM
Compound 4: the middle estimate sits 1.4-fold (0.14 log units) below what was measured; the range from low to high includes it.
By their numbers in this assay, from the lowest: compounds 1, 2, 3 and 4 (each within the scatter of the next, the first and the last beyond it).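

Read directly for the first time, the exchange of cyclopentyl for phenyl on this oxygen gives in this assay a 1.5-fold higher number from compound 2 to compound 4 (0.18 log units; within the scatter). A five-membered non-aromatic ring of carbon and a six-membered aromatic ring therefore cannot be told apart at this place by growth inhibition in these cells. Among the compounds shown here, the single pair thus shows that this place tolerates either ring without a step that stands out from repeat measurements, and nothing measured here offers an explanation for the small difference.

The compounds shown leave open whether a group other than these two rings on the same oxygen, such as a methyl, a longer chain like butyl, or a pyridyl ring, would give a real step. They also leave open whether a ring bearing an amine or a carboxylic acid would do so.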